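This account rests on a few compounds, and the source may have more. Where it says the series, first, only, none or still open, it means among the compounds named here.

Measured compounds in a functional assay on Ehrlich cells (Mus musculus) for cytotoxicity; a lower number here means a stronger inhibitor, a higher number a weaker inhibitor:
- compound 1 `COc1cc(N2C(N)=C(C#N)C(c3c(O)ccc4ccccc34)C3=C2CC(C)(C)CC3=O)cc(OC)c1OC`: 143000 nM
- compound 2 `COc1ccccc1C1C(C#N)=C(N)N(c2cc(OC)c(OC)c(OC)c2)C2=C1C(=O)CC(C)(C)C2`: 26600 nM
- compound 3 `COc1cc(N2C(N)=C(C#N)C(c3ccccc3Cl)C3=C2CC(C)(C)CC3=O)cc(OC)c1OC`: "not active" (no number reported), no number given

Compound 1 stands highest of the two numbers; the nearest is compound 2, reached by a 5.4-fold lower number from compound 1 to compound 2 (0.73 log units; beyond the scatter), a modest step. Compound 4 `COc1cc(N2C(N)=C(C#N)C(/C=C/c3ccccc3)C3=C2CC(C)(C)CC3=O)cc(OC)c1OC` differs from compound 1 as follows: 2-phenylethenyl in place of 2-hydroxynaphthalen-1-yl on a saturated ring carbon. Among the compounds with values here, the only step with a bearing is the exchange of the same group in compound 1 for a smaller aryl in compound 2, which lowered the number, while compound 3, another exchange at that carbon, gave no activity at all. The direction is thus uncertain; a shift toward a lower number is expected, but with a wide range. Compound 4 is estimated at 60000 nM (range 15000 nM to 250000 nM), a step of a 2.4-fold lower number from compound 1 to compound 4 (0.38 log units; beyond the scatter) from compound 1 being expected.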

Compound 4, half-maximal inhibitory concentration: "not active" (no number reported)
Nothing numeric was reported for compound 4; no gap can be computed for the estimate.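

Within the data shown here, compound 4, like compound 3, is reported as "not active" in this assay without a number, so no step from compound 1 can be read. The compounds shown leave open which groups at this saturated ring carbon give a measurable value. No measured evidence bears on this result.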